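Trading a tert-butyl for fluorine and methyl on the aniline

The compounds below may be only part of what the source reports. "The series", "measured", "known", "first", "only" and "open" are said of these compounds alone.

Of the compounds shown here, three of one series have been tested in a functional assay on NCI-H1581 cells (Homo sapiens) for inhibition, read by MTT assay, with a stated time of 48 h, tested at 10 uM; a higher number here means more inhibition at the concentration tested (going by the name of the read-out), a lower number less inhibition. Compound 1 `Cc1cc(F)cc(Nc2cc(NC(=O)Nc3c(Cl)cccc3Cl)ncn2)c1` gives 65.1%. Compound 2 `COc1cc(NC(=O)Nc2cc(Nc3cccc(C(C)(C)C)c3)ncn2)cc(OC)c1` gives 35.1%, and compound 3 `COc1cc(Nc2cc(NC(=O)Nc3c(Cl)cccc3Cl)ncn2)cc(C(F)(F)F)c1` gives 32.3%. Compound 2 therefore sits far beneath compound 1, a gap well beyond the usual scatter, while its value and that of compound 3 lie within the scatter of each other and cannot be told apart.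

Compound 4 `COc1cc(NC(=O)Nc2cc(Nc3cc(C)cc(F)c3)ncn2)cc(OC)c1` has not yet been measured. It differs from compound 2 in one place: 3-fluoro-5-methylphenyl in place of 3-(tert-butyl)phenyl on a nitrogen on an aromatic ring. Among the measured compounds shown here, no pair of measured compounds differs by exactly this change, so the data give no direct step to lean on. The same 3-fluoro-5-methylphenyl group does appear in compound 1, whose value of 65.1% is the highest shown, although compound 1 also carries a different urea partner, so the comparison is loose. A modest rise in this assay is expected, of the size a number 9.9 percentage points higher from compound 2 to compound 4 (within the scatter), but it could well fall within the scatter. Compound 4 is estimated at 45%, with a likely range from 25% to 65%.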

Compound 4, a percentage reported as inhibition, at one concentration (the size of the read-out at that concentration, not a potency): 28.3%
The estimate for compound 4 lay 16.7 percentage points above the measured number, within the range that was stated.
By their numbers in this assay, from the lowest: compounds 4, 3 and 2 (each within the scatter of the next); then compound 1.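

In this assay, putting 3-fluoro-5-methylphenyl in place of 3-(tert-butyl)phenyl on this nitrogen gives a number 6.8 percentage points lower from compound 2 to compound 4 (within the scatter), so with this urea partner the two groups cannot be told apart. The high reading of compound 1 does not come with the 3-fluoro-5-methylphenyl group alone: compound 1 gives 65.1%, while compound 4, which carries the same group with a different urea partner, gives 28.3%. Nothing measured here offers an explanation for either result.

From the compounds shown here alone, it remains open whether 3-(tert-butyl)phenyl and 3-fluoro-5-methylphenyl would also match each other when paired with the urea partner of compound 1. Also open, going by these compounds, is how an amine or a carboxylic acid on the aromatic ring at this nitrogen would read out in this assay.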